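Adding one methyl to the ethoxy group of compound 2

The source may hold more compounds than are shown below. What is called first, only, known or untested is meant among the compounds shown, and "the series" means these compounds.

Measured in a toxicity assay on microsomes from liver (Homo sapiens) for metabolic stability, read by LC-MS, using NADPH, tested at 1 uM; on this read-out higher numbers stand for fast clearance and lower numbers for slow clearance:
Compound 1 `CCOc1ncc(-c2nc(C(F)(F)F)sc2N2CCN(C(=O)Cn3ccc4cnccc43)[C@H](C)C2)cn1`: 656 mL.min-1.g-1
Compound 2 `CCOc1ncc(-c2nc(C(F)(F)F)sc2N2CCN(C(=O)Cn3nc(C)nc3C)[C@H](C)C2)cn1`: < 10 mL.min-1.g-1, a limit and not a number

On these data alone, compound 2 stands at the limit of < 10 mL.min-1.g-1 in this assay, at which 1 of the 2 values shown sits, so its exact clearance is unknown. Compound 3 `Cc1nc(C)n(CC(=O)N2CCN(c3sc(C(F)(F)F)nc3-c3cnc(OC(C)C)nc3)C[C@H]2C)n1` carries one change, methyl in place of hydrogen on a saturated chain carbon bound to an oxygen on an aromatic ring and a saturated chain carbon, or ethoxy to isopropoxy. Among the measured compounds shown here, the only measured step, an at least 65-fold lower number from compound 1 to compound 2 (1.81 log units; beyond the scatter), was large, but it arose on a saturated chain carbon bound to a carbonyl carbon and does not bear directly on this change. For the measured compounds named here, with no measured step for this change, only a small upward step is expected in this assay. That expectation amounts to an at least 1.2-fold higher number from compound 2 to compound 3 (0.07 log units; that floor lies within the scatter). For compound 3 the estimated clearance is 12 mL.min-1.g-1, with an expected range of 5 mL.min-1.g-1 to 35 mL.min-1.g-1.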

Compound 3, intrinsic clearance in microsomes: 16 mL.min-1.g-1
For compound 3 the middle estimate is 1.3-fold (0.12 log units) below the measured one; the range from low to high includes it.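

In this assay, among the compounds shown here, the first step at this position, ethoxy to isopropoxy, reads an at least 1.6-fold higher number from compound 2 to compound 3 (0.20 log units; that floor lies within the scatter) for one added methyl on the saturated chain carbon bound to an oxygen on an aromatic ring and a saturated chain carbon. For compound 2 the value < 10 mL.min-1.g-1 is a limit of the assay and not a number, whereas compound 3 gives an exact value. The true size of the step stays unknown and only its floor can be read, because one end of it rests on a limit: the limit of < 10 mL.min-1.g-1 in this assay, at which 1 of the 3 values shown sits.

The compounds shown leave open how clearance responds to a smaller or a longer group on this oxygen, such as methoxy or a longer chain like n-propoxy. They also leave open whether isopropoxy behaves the same way with the amide side chain of compound 1.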